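Two ureas with no measurable effect, and an enantiomer

This account rests on a few compounds, and the source may have more. Where it says the series, first, only, none or still open, it means among the compounds named here.

Measured so far:
Compound 1, `C[C@H](NC(=O)Nc1ccccc1C(C)(C)C)c1ccccc1`: in an ADME assay on the whole organism with Oryza sativa as the target, tested at 0.1 uM (on this read-out lower numbers stand for a stronger effect and higher numbers for a weaker effect at the one concentration tested), compound 1 gives 101%.
Compound 2, `C[C@@H](NC(=O)Nc1cc(C(C)(C)C)ccc1C(C)(C)C)c1ccccc1`: in this assay compound 2 gives 100%.

Compound 2 stands alongside compound 1 in this assay, the two numbers lying within the usual scatter of each other, so neither can be told apart from the other, and both read as no effect at the concentration tested. Compound 3, `C[C@H](NC(=O)Nc1cc(C(C)(C)C)ccc1C(C)(C)C)c1ccccc1`, is the next compound to be measured in this assay. How it differs from compound 2: the two compounds have the same atoms and bonds and differ only in configuration as drawn: 1 of 1 stereo elements differ; a stereocentre at a saturated chain carbon is drawn R in compound 2 and S in compound 3. Going by the values given here, no step between two measured compounds is available to guide the expectation; the only footing is that compound 2, carrying the same atoms and bonds, gives 100%. On that footing no step beyond the scatter is expected in this assay for compound 3, in either direction, and the expected step is no change at the digits printed from compound 2 to compound 3 (within the scatter). Compound 3 is therefore estimated at 100%, within a range from 90% to 110%.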

Compound 3, a percentage reported as activity, at one concentration (the size of the read-out at that concentration, not a potency): 98%
Beside the measured number, compound 3's estimate is 2 percentage points above it; the measured number falls inside the stated range.
By their numbers in this assay, from the lowest: compounds 3, 2 and 1 (each within the scatter of the next).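

In this assay, turning the stereocentre at the saturated chain carbon from R to S gives a number 2 percentage points lower from compound 2 to compound 3 (within the scatter), so the read-out does not separate the two configurations at the one concentration tested. Going by these compounds alone, this is the first comparison that isolates configuration, and it can be read that way for one reason: the fact that compounds 2 and 3 differ only in the configuration as drawn The second tert-butyl gives no separation either, since tert-butyl in place of hydrogen on an aromatic carbon amounts to a number 3 percentage points lower from compound 1 to compound 3 (within the scatter).

Both changes therefore leave the read-out within the scatter, and neither points to a feature of these ureas that moves it. Going by these compounds, whether an amine or a carboxylic acid in place of a tert-butyl, or a longer chain at the stereocentre, would shift the number in this assay remains open, as does the behaviour of either configuration at any other concentration.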